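A few compounds are considered here, and "the series" means these few. Any claim that something is new, unique, unknown or untested is made for them only; others in the source may bear on it.

Measured so far in a functional assay on HL-60 cells (Homo sapiens) for cytotoxicity, with a stated time of 48 h; a lower number here means that less compound is tolerated, a higher number that more compound is tolerated:

Compound 1 `Cc1c(C(=O)/C=C/c2ccc(Cl)cc2)[n+]([O-])c2ccccc2[n+]1[O-]` — 11000 nM
Compound 2 `COc1ccc(/C=C/C(=O)c2c(C)[n+]([O-])c3ccccc3[n+]2[O-])cc1OC` — 14000 nM
Compound 3 `Cc1c(C(=O)/C=C/c2ccc(Br)cc2)[n+]([O-])c2ccccc2[n+]1[O-]` — 23000 nM

Compound 3 gives the highest of the three numbers, meaning the cells tolerate the most of it. Its nearest neighbour is compound 2, whose number is lower by a margin within the scatter, so the two cannot be ranked against each other. Compound 1 lies furthest off: the step of a 2.1-fold higher number from compound 1 to compound 3 (0.32 log units; beyond the scatter) is beyond the scatter, though modest.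

The next compound, compound 4 `COc1ccc(/C=C/C(=O)c2c(C)[n+]([O-])c3ccccc3[n+]2[O-])cc1`, differs from compound 3 in one place: methoxy in place of bromo on an aromatic carbon. Within the data shown here, no measured step makes exactly this swap. Among the measured compounds shown here, the single measured step, a 2.1-fold higher number from compound 1 to compound 3 (0.32 log units; beyond the scatter), exchanges one halogen for another at the same place and says little about a methoxy. Compound 2, however, carries a methoxy at this place together with a second methoxy, and its value sits within the scatter of that of compound 3. On that basis the expected step of a 1.4-fold lower number from compound 3 to compound 4 (0.16 log units; within the scatter) stays within the scatter, leaning if anything toward a lower number because compound 2 gives 14000 nM. Compound 4 is therefore estimated at 16000 nM, with a range from 7000 nM to 35000 nM.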

Compound 4, half-maximal cytotoxic concentration: 16000 nM
Compound 4: middle estimate and measured number agree at the digits printed, and the stated range covers the measured number.
By their numbers in this assay, from the lowest: compounds 1, 2, 4 and 3 (each within the scatter of the next, the first and the last beyond it).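

In this assay, 4-methoxyphenyl in place of 4-bromophenyl gives no readable change (a 1.4-fold lower number from compound 3 to compound 4 (0.16 log units; within the scatter)), and methoxy in place of chloro at the same place gives none either (a 1.5-fold higher number from compound 1 to compound 4 (0.16 log units; within the scatter)). Taking away the second methoxy of compound 2 leaves the reading just as unmoved (a 1.1-fold higher number from compound 2 to compound 4 (0.06 log units; within the scatter)), so in this set one methoxy and two cannot be told apart, and the single methoxy cannot be told apart from either halogen. Among these compounds, the one gap beyond the scatter in this small set therefore remains the one between the chloro compound 1 and the bromo compound 3, with compound 4 unresolved from both, and nothing measured here offers an explanation for these numbers.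

All four compounds share the same core and differ only on the outer aromatic ring, so the numbers say nothing about changes elsewhere in the molecule. On these data alone, it also remains open how this place would respond to a quite different group, such as an amine, a carboxylic acid or a longer chain like butoxy.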